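The compounds below may be only part of what the source reports. "The series", "measured", "known", "first", "only" and "open" are said of these compounds alone.

Three measured compounds share the same assay, a functional assay on A549 cells (Homo sapiens) for cytotoxicity, read by MTT assay, with a stated time of 72 h; on this read-out lower numbers stand for stronger inhibition and higher numbers for weaker inhibition. Compound 1 `O=C(Nc1ccc(Oc2ccnc3[nH]ccc23)cc1)c1nccc(-c2cccc(Cl)c2)n1` gives 4120 nM in this assay. Compound 3 `O=C(Nc1ccc(Oc2ccnc3[nH]ccc23)c(F)c1)c1nccc(-c2cccc(Cl)c2)n1` differs from compound 1 by a single change, (fluoro in place of hydrogen on an aromatic carbon), and this change brought a 9.2-fold lower number from compound 1 to compound 3 (0.96 log units; beyond the scatter). In this assay compound 3 gives 450 nM. Compound 2 `O=C(Nc1ccc(Oc2ccnc3[nH]ccc23)cc1)c1cc(-c2ccccc2)ncn1` is built on a different core; the difference between the two cores is not broken down here. In this assay compound 2 gives 140 nM, the lowest of the three numbers, with compound 3 nearest to it and compound 1 furthest away.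

Compound 4 `O=C(Nc1ccc(Oc2ccnc3[nH]ccc23)c(F)c1)c1cc(-c2ccccc2)ncn1` has not been measured. Among the measured compounds shown here, it is related to compound 2 by fluoro in place of hydrogen on an aromatic carbon, which is the same change as the one from compound 1 to compound 3, placed in the same way. For the measured compounds named here, that one measured example of the change was made on the core of compound 1, whereas compound 4 carries the core of compound 2, and no second example exists, so the size of the step can only be carried over with caution. Compound 4 is expected to show a lower number than compound 2 because a 9.2-fold lower number from compound 1 to compound 3 (0.96 log units; beyond the scatter) points in that direction. The step expected from compound 2 to compound 4 is a 2.8-fold lower number from compound 2 to compound 4 (0.45 log units; beyond the scatter), deliberately smaller than the measured one. Compound 4 is therefore estimated at 50 nM, with a plausible range from 15 nM to 200 nM.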

Compound 4, half-maximal inhibitory concentration: 180 nM
For compound 4 the middle estimate is 3.6-fold (0.56 log units) below the measured one; measured number inside the range.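

On the core of compound 2, fluoro in place of hydrogen on an aromatic carbon gives a 1.3-fold higher number from compound 2 to compound 4 (0.11 log units; within the scatter) in this assay, so compound 2 and compound 4 cannot be told apart on this read-out. The gain seen on the core of compound 1 therefore did not carry over to the core of compound 2, and the two results differ by more than repeated measurements would explain: the same change on two cores in this assay, a 9.2-fold lower number (0.96 log units; beyond the scatter) from compound 1 to compound 3 and a 1.3-fold higher number (0.11 log units; within the scatter) from compound 2 to compound 4, 12-fold (1.07 log units) apart, beyond the scatter of two such steps

Among the compounds shown here, this shows that, in this series, the size of the step from this change cannot simply be transferred from one core to another, but it does not show which structural difference between the two cores is responsible, why the outcomes differ, or how the change would behave on a third core, since only two pairs are available.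

The compounds shown leave open whether a chlorine atom or a methoxy group on the same aromatic carbon would also depend on the core in this way. They also leave open whether fluoro would give a clear step or none on a related core carrying an added amine or a carboxylic acid.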